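An isomeric exchange on the shared core

The compounds below may be only part of what the source reports. "The series", "measured", "known", "first", "only" and "open" are said of these compounds alone.

Measured in a physicochemical assay for lipophilicity, at pH 7.4; a lower number here means a more polar compound, a higher number a more lipophilic compound:
Compound 1 `Cc1cc(C)c(CN2CCc3c(Cl)cc([C@H](CO)[C@H]4CCOC4)c(Cl)c3C2=O)c(=O)[nH]1`: 2
Compound 2 `COC(c1cc(Cl)c2c(c1Cl)C(=O)N(Cc1c(C)cc(C)[nH]c1=O)CC2)C1CCOCC1`: 3.4; 3.5 (2 entries)

Compound 1 stands at 2, the lower of the two measured compounds, and a further entry for it carries no single number. Compound 3 `Cc1cc(C)c(CN2CCc3c(Cl)cc([C@@H](CO)[C@@H]4CCCO4)c(Cl)c3C2=O)c(=O)[nH]1` has the same atoms as compound 1, joined differently: a group of 8 heavy atoms (6 carbon, 2 oxygen; one five-membered non-aromatic ring with 1 hetero atom) in place of a group of 8 heavy atoms (6 carbon, 2 oxygen; one five-membered non-aromatic ring with 1 hetero atom), on an aromatic carbon. Going by the values given here, no measured step between close relatives is available, so no change beyond the scatter is expected in this assay, with any drift slightly upward. The expected size is a number 0.20 log units higher from compound 1 to compound 3 (within the scatter). For compound 3 the estimated value is 2.2, with an expected range from 1.8 to 2.6.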

Compound 3, distribution coefficient: 2.1
For compound 3 the middle estimate is 0.10 log units above the measured one, and the stated range covers the measured number.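

In this assay, moving to the isomeric group on the same aromatic carbon, ortho to a chloro group, gives a number 0.10 log units higher from compound 1 to compound 3 (within the scatter). For this pair, then, rejoining the same atoms around a five-membered non-aromatic ring with 1 hetero atom leaves the distribution coefficient within the usual scatter. Repeat readings in this assay agree closely for the one compound entered twice: the several entries of compound 2 in this assay, 3.4; 3.5 (2 entries)

On these data alone, it remains open whether an amine or a carboxylic acid in this group would shift the distribution coefficient beyond the scatter. As far as these compounds go, the behaviour of the other stereoisomers of either group also remains open.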